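The source may report more compounds than this note shows. Statements on the series, on what has been measured and on what is new or still open speak of the compounds shown alone.

Of the compounds shown here, two of one shared core have so far been measured in an assay on isolated protein for inhibition of histone deacetylase HD1B (Zea mays); a lower number here means a stronger inhibitor, a higher number a weaker inhibitor. Compound 1 `Cn1cc(/C=C/C(=O)c2ccccc2F)cc1/C=C/C(=O)NO` carries a 2-fluorophenyl group on the carbonyl carbon of its side chain, and in this assay compound 1 gives 3400 nM. Compound 2 `Cn1cc(/C=C/C(=O)c2ccc3ccccc3c2)cc1/C=C/C(=O)NO` carries a naphthalen-2-yl group at the same position; in this assay compound 2 gives 1800 nM. Of the two numbers, that of compound 1 is the one standing at the upper end, but the gap to compound 2 lies within the usual scatter of repeated measurements, so the two compounds cannot be told apart on these data.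

Compound 3 `Cn1cc(/C=C/C(=O)c2cccs2)cc1/C=C/C(=O)NO` has not yet been measured in this assay. It differs from compound 1 in one place: thiophen-2-yl in place of 2-fluorophenyl on a carbonyl carbon. Going by the values given here, no step between measured compounds of this kind is available, so the expectation rests on the two values given and on the fact that both aryl ketones fall close together. Compound 3 is expected to stay near compound 1, with a step from compound 1 to compound 3 of a 1.4-fold lower number from compound 1 to compound 3 (0.13 log units; within the scatter), which is not beyond the scatter. The estimate for compound 3 in this assay is 2500 nM, within a range from 1000 nM to 6000 nM.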

Compound 3, half-maximal inhibitory concentration: 25800 nM
Compound 3: the middle estimate sits 10-fold (1.01 log units) below what was measured, outside the stated range (above it).
By their numbers in this assay, from the lowest: compounds 2 and 1 (each within the scatter of the next); then compound 3.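

In this assay the group on the carbonyl carbon of the side chain proves able to separate compounds of this shared core: thiophen-2-yl in place of 2-fluorophenyl gives a 7.6-fold higher number from compound 1 to compound 3 (0.88 log units; beyond the scatter) and this step lies beyond the scatter, whereas the two earlier compounds could not be told apart. Compound 2, with its naphthalen-2-yl group, gives 1800 nM and compound 3 gives 25800 nM, so the larger printed number belongs to the compound with the thiophen-2-yl group in this set of three. The change from compound 1 to compound 3 replaces one six-membered aromatic ring of carbon only with one five-membered aromatic ring with 1 hetero atom, but the data shown offer nothing on what lies behind the step.

The compounds shown leave open whether the step follows from the thiophen-2-yl group itself or from the loss of the fluorine, a question that an unsubstituted phenyl group or a thiophen-3-yl group at this carbonyl carbon would help to settle. They also leave open how a pyridin-3-yl group or a phenyl group bearing a dimethylamino substituent would stand at the same place.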